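The source may report more compounds than this note shows. Statements on the series, on what has been measured and on what is new or still open speak of the compounds shown alone.

Measured so far in a functional assay on CHO cells for antagonist activity at adenosine receptor A2b (Homo sapiens), read by 33P incorporation, with a stated time of 20 min; on this read-out lower numbers stand for stronger inhibition and higher numbers for weaker inhibition:
compound 1 `CCn1c(-c2ccccc2)nc2c(NC3CCC3)ncnc21` — 1440 nM
compound 2 `CCn1c(-c2ccccc2)nc2c(NC3CCCC3)ncnc21` — 5790 nM
compound 3 `CCn1c(-c2ccccc2)nc2c(NC3CCOC3)ncnc21` — 11500 nM

Among these three numbers compound 2 stands second highest. Its nearest neighbour is compound 3: the step of a 2.0-fold higher number from compound 2 to compound 3 (0.30 log units; within the scatter) lies within the scatter, so no order between the two can be claimed. The step of a 4.0-fold higher number from compound 1 to compound 2 (0.60 log units; beyond the scatter) is beyond the scatter, as is an 8.0-fold higher number from compound 1 to compound 3 (0.90 log units; beyond the scatter). Every one of these steps exchanges the ring on a nitrogen on an aromatic ring; none of them alters the saturated chain.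

Compound 4 `CCCn1c(-c2ccccc2)nc2c(NC3CCCC3)ncnc21` differs from compound 2 by methyl in place of hydrogen on a saturated chain carbon, two bonds along the chain from an aromatic nitrogen. Read one bond further out, this is ethyl to propyl. For the measured compounds named here, no measured pair varies that chain, so there is no step of known size that bears on the change; the measured steps concern a different position and give no direction. The expectation is therefore a number close to that of compound 2, with nothing beyond the scatter, and a wide range to reflect the lack of precedent. Compound 4 is expected to give 6000 nM, with a range from 2000 nM to 18000 nM. The expected step is a 1.0-fold higher number from compound 2 to compound 4 (0.02 log units; within the scatter).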

Compound 4, inhibition constant: 3430 nM
Estimate against measurement, compound 4: 1.7-fold (0.24 log units) above; the range from low to high includes it.
By their numbers in this assay, from the lowest: compound 1; then compounds 4, 2 and 3 (each within the scatter of the next, the first and the last beyond it).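

In this assay methyl in place of hydrogen on a saturated chain carbon, two bonds along the chain from an aromatic nitrogen, gives a 1.7-fold lower number from compound 2 to compound 4 (0.23 log units; within the scatter) and this ethyl to propyl change cannot be told from the scatter. For the compounds shown here, this is the only reading of the chain so far, as the earlier steps all exchanged the ring on a nitrogen on an aromatic ring, and it covers a single pair with cyclopentyl kept in both compounds. No measurement at hand bears on this result or accounts for it.

Still open, as far as these compounds go, is whether the position stays this flat with a longer chain such as butyl, a branched chain such as isopropyl, or a chain ending in an amine or a hydroxyl group. Also open, from the compounds shown here alone, is whether ethyl to propyl gives a step of similar size with the cyclobutyl group of compound 1 in place of cyclopentyl.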